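Notes on removal of the pentyloxy group in the series

A few compounds are considered here, and "the series" means these few. Any claim that something is new, unique, unknown or untested is made for them only; others in the source may bear on it.

Measured so far in a functional assay on the whole organism for activation, with Mus musculus as the target; a higher number here means that more compound is needed for the effect, a lower number that less compound is needed:
compound 1, `Cc1nc(N)c2nc(O)n(Cc3ccccc3)c2n1` — 3 mg/kg
compound 2, `CCSc1nc(N)c2nc(O)n(Cc3ccccc3)c2n1` — 0.1 mg/kg
compound 3, `CCCCCOc1nc(N)c2nc(O)n(Cc3ccccc3)c2n1` — 0.3 mg/kg

Compound 3 stands second highest of the three numbers; its nearest neighbour is compound 2, with a 3.0-fold higher number from compound 2 to compound 3 (0.48 log units; beyond the scatter), and the furthest is compound 1, with a 10-fold lower number from compound 1 to compound 3 (1.00 log units; beyond the scatter). Compound 4 is `Nc1ncnc2c1nc(O)n2Cc1ccccc1`, not yet measured. It differs from compound 3 in one place: hydrogen in place of pentyloxy on an aromatic carbon.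

For the measured compounds named here, no measured step removes a group to leave hydrogen, so the steps that bear on it are indirect. Going from methyl to a larger group on this carbon lowered the dose in both cases: a 30-fold lower number from compound 1 to compound 2 (1.48 log units; beyond the scatter) and a 10-fold lower number from compound 1 to compound 3 (1.00 log units; beyond the scatter). Compound 4 goes the other way, to a smaller group than any measured, so the dose is expected to rise beyond the scatter from compound 3, plausibly back to the level of compound 1 or higher. The expected step is a 10-fold higher number from compound 3 to compound 4 (1.00 log units; beyond the scatter). For compound 4 in this assay the estimate is 3 mg/kg, with a range from 0.8 mg/kg to 12 mg/kg. The range is wide since the effect of a hydrogen at this carbon is unmeasured here.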

Compound 4, minimum effective dose: 30 mg/kg
Estimate against measurement, compound 4: 10-fold (1.00 log units) below; the measured number lies above the stated range.
By their numbers in this assay, from the lowest: compound 2; then compound 3; then compound 1; then compound 4.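

In this assay, hydrogen on this aromatic carbon between two ring nitrogen atoms gives the highest number of the series, and the loss of the pentyloxy chain carries a large cost (a 100-fold higher number from compound 3 to compound 4 (2.00 log units; beyond the scatter)), with a still larger one on the loss of ethylsulfanyl (a 300-fold higher number from compound 2 to compound 4 (2.48 log units; beyond the scatter)). Methyl, the smallest of the measured groups, also stands clearly apart from hydrogen (a 10-fold higher number from compound 1 to compound 4 (1.00 log units; beyond the scatter)), so all three substituents give lower numbers than hydrogen, and the gain at this position is not confined to the two larger groups. No measurement on hand accounts for the size of these steps or identifies what any of these groups does at this carbon.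

Ethylsulfanyl and pentyloxy differ in both the linking atom and the chain, so the series does not separate the two; ethoxy and pentylsulfanyl would do so. On these data alone, it is also open whether the low numbers depend on a linking heteroatom at all, which a simple ethyl or pentyl chain would test, and whether an amine at this carbon would behave like the ether and the thioether.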